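The source may hold more compounds than are shown below. What is called first, only, known or untested is meant among the compounds shown, and "the series" means these compounds.

Compound 1, `O=C(Nc1cccc(-n2cc(-c3ccncc3)c(-c3ccc(Cl)c(O)c3)n2)c1)Nc1cccc(C(F)(F)F)c1`, is a diaryl urea built on a shared core, and in a functional assay on DU-145 cells (Homo sapiens) for inhibition, read by sulforhodamine B assay, with a stated time of 48 h (a lower number here means a stronger inhibitor of growth, a higher number a weaker inhibitor of growth), compound 1 gives 1760 nM. Compound 2, `COc1cc(-c2nn(-c3cccc(NC(=O)Nc4cccc(C(F)(F)F)c4)c3)cc2-c2ccncc2)ccc1Cl`, differs from it by a methyl in place of hydrogen on an oxygen on an aromatic ring, and in this assay compound 2 gives 1670 nM; the step of a 1.1-fold lower number from compound 1 to compound 2 (0.02 log units; within the scatter) lies within the scatter. Among the two measured numbers compound 1 has the highest, with compound 2 a near neighbour. Compound 3, `O=C(Nc1cccc(-n2cc(-c3ccncc3)c(-c3ccc(Cl)c(O)c3)n2)c1)Nc1ccc(Cl)c(C(F)(F)F)c1`, carries a different change: chloro in place of hydrogen on an aromatic carbon. Going by the values given here, no measured step touches this part of the molecule, so nothing measured bears directly on the change; the only step known, from compound 1 to compound 2, was within the scatter on another ring. Compound 3 is therefore expected to give about 1500 nM, in a range from 600 nM to 3800 nM, which means an estimated step of a 1.2-fold lower number from compound 1 to compound 3 (0.07 log units; within the scatter).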

Compound 3, concentration for 50% growth inhibition: 1130 nM
Estimate against measurement, compound 3: 1.3-fold (0.12 log units) above; low and high end bracket the measured number.
By their numbers in this assay, from the lowest: compounds 3, 2 and 1 (each within the scatter of the next).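

At the position ortho to a trifluoromethyl group and para to a large group, chloro can take the place of hydrogen without a clear effect on growth inhibition: in this assay there is a 1.6-fold lower number from compound 1 to compound 3 (0.19 log units; within the scatter) and so no real difference between the two compounds. Going by these compounds alone, this is the first reading from the ring carrying the trifluoromethyl group, and it shows that this added atom does not shift the number beyond normal variation. Nothing available offers an explanation for the size of this step.

The compounds shown leave open whether a group of a different kind at this position, such as an amine or a carboxylic acid, would give a step beyond the scatter. They also leave open whether chloro here would behave the same way alongside the methoxy group of compound 2.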